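From compound 3 to compound 4: a ring swap on the chain

The source may report more compounds than this note shows. Statements on the series, on what has been measured and on what is new or still open speak of the compounds shown alone.

Measured in a functional assay on KB cells (Homo sapiens) for cytotoxicity; a higher number here means that more compound is needed for the effect, a lower number that less compound is needed:
compound 1 `COC1=C(C)C(=O)/C(=C(O)/C=C/c2ccc(Br)cc2)C(=O)C1(C)C` - 1.9 ug/mL
compound 2 `COC1=C(C)C(=O)/C(=C(O)/C=C/c2cccc(OC)c2)C(=O)C1(C)C` - 2.4 ug/mL
compound 3 `COC1=C(C)C(=O)/C(=C(O)/C=C/c2cc(C)cc(C)c2)C(=O)C1(C)C` - 1.6 ug/mL

Compound 3 (at 1.6 ug/mL) cannot be separated from compound 1 or compound 2, since all three numbers lie within the scatter of each other. Compound 4 `COC1=C(C)C(=O)/C(=C(O)/C=C/c2nccs2)C(=O)C1(C)C` has not yet been measured. The change leading to it is 1,3-thiazol-2-yl in place of 3,5-dimethylphenyl on a double-bonded chain carbon bound to a double-bonded chain carbon, with 1,3-thiazol-2-yl in place of 3,5-dimethylphenyl on a double-bonded chain carbon bound to a double-bonded chain carbon.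

Three measured steps at this place bear on it: a 1.3-fold higher number from compound 1 to compound 2 (0.10 log units; within the scatter), a 1.2-fold lower number from compound 1 to compound 3 (0.07 log units; within the scatter) and a 1.5-fold lower number from compound 2 to compound 3 (0.18 log units; within the scatter). For the measured compounds named here, all three are small, but none brings in a five-membered aromatic ring, so the data hold no direct precedent for the entering group. No step beyond the scatter is therefore expected in this assay, and the range is kept wide on the upper side. The expected step is a 1.6-fold higher number from compound 3 to compound 4 (0.19 log units; within the scatter). For compound 4 the estimated value is 2.5 ug/mL, with an expected range from 1.2 ug/mL to 5.5 ug/mL.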

Compound 4, concentration for half-maximal effect: 3 ug/mL
For compound 4 the middle estimate is 1.2-fold (0.08 log units) below the measured one; the measured number falls inside the stated range.
By their numbers in this assay, from the lowest: compounds 3, 1, 2 and 4 (each within the scatter of the next).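

In this assay, for the compounds shown here, the 1,3-thiazol-2-yl group is the first five-membered aromatic ring with hetero atoms at this place, and it remains within the scatter of all three aryl compounds (a 1.9-fold higher number from compound 3 to compound 4 (0.27 log units; within the scatter); a 1.3-fold higher number from compound 2 to compound 4 (0.10 log units; within the scatter); a 1.6-fold higher number from compound 1 to compound 4 (0.20 log units; within the scatter)). The position therefore accepts a change from a six-membered aromatic ring of carbon only to this smaller ring carrying nitrogen and sulfur, with no step beyond the scatter. No available evidence explains this flat response or connects it to any property of the groups.

On these data alone, it remains open whether any group on the double-bonded chain carbon can move the number beyond the scatter, for example a carboxylic acid, a primary amine or a saturated piperidine ring. As far as these compounds go, with only this one cell line, it also remains open whether the compounds act differently on other cells.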